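Swapping a sulfur-linked chain for an ether on the shared core

The compounds below may be only part of what the source reports. "The series", "measured", "known", "first", "only" and "open" are said of these compounds alone.

Of the compounds shown here, three sharing one core have been measured in a functional assay on ileum for inhibition of histamine H1 receptor (Cavia porcellus); a higher number here means a weaker inhibitor, a lower number a stronger inhibitor. Compound 1, `CCSCCn1c(N2CCN(C)CC2)nc2ccccc21`, gives 19 nM in this assay. Compound 2, `CCOCCn1c(N2CCCN(Cc3ccccc3)CC2)nc2ccccc21`, gives 15 nM, and compound 3, `CCCCCN1CCN(c2nc3ccccc3n2CCOCC)CC1`, gives 30 nM. On these numbers compound 1 stands second highest of the three; its nearest neighbour is compound 2, whose number sits within the usual scatter of it, and its furthest is compound 3, whose number also sits within that scatter. For the measured compounds named here, no one-place step between measured compounds is available, so the three values show only that all of them lie close together.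

Compound 4, `COCCCn1c(N2CCN(C)CC2)nc2ccccc21`, has not yet been measured in this assay. It differs from compound 1 by one change: methoxymethyl in place of ethylsulfanyl on a saturated chain carbon, two bonds along the chain from an aromatic nitrogen. Going by the values given here, every group counted in this exchange matches the one it replaces in number of heavy atoms, in the absence of a ring and in the count of donors and acceptors; only the heteroatom changes.

On the record of these three compounds, compound 4 is expected to stay close to compound 1, with the step of a 1.3-fold higher number from compound 1 to compound 4 (0.12 log units; within the scatter) estimated as none beyond the scatter. Compound 4 is therefore estimated at 25 nM in this assay, within a range from 8 nM to 80 nM.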

Compound 4, half-maximal inhibitory concentration: 860 nM
Compound 4: middle estimate off by 34-fold (1.54 log units), on the low side, outside the stated range (above it).
By their numbers in this assay, from the lowest: compounds 2, 1 and 3 (each within the scatter of the next); then compound 4.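

In this assay, methoxymethyl in place of ethylsulfanyl on a saturated chain carbon, two bonds along the chain from an aromatic nitrogen, gives a 45-fold higher number from compound 1 to compound 4 (1.66 log units; beyond the scatter), so this position is not indifferent to the exchange, although the number of heavy atoms, the absence of a ring and the counts of donors and acceptors all stay the same. The earlier compounds shown here, with no one-place step among them and all within the scatter of their nearest neighbours, could not show that a change at this place alone can produce a step of this size. Nothing available here bears on why the step is so large.

Read one bond further out, the change is 2-(ethylsulfanyl)ethyl to 3-methoxypropyl, so the exchange of sulfur for oxygen and the shift of that atom along the chain arrive together, and this single pair cannot tell them apart. From the compounds shown here alone, a 3-(methylsulfanyl)propyl chain on the core of compound 1 would keep the sulfur at the place the oxygen holds in compound 4, and how such a chain reads in this assay remains open.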